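Butyl to propyl on the diamino core

The source may hold more compounds than are shown below. What is called first, only, known or untested is meant among the compounds shown, and "the series" means these compounds.

Compound 2 `CCCCc1nc(N)nc(N)c1-c1ccc(Cl)cc1` stands in an assay for inhibition of beta-N-acetyl-D-hexosaminidase-A/B (Homo sapiens) (a lower number here means a stronger inhibitor, a higher number a weaker inhibitor), at > 1400000 nM, which is a limit of the assay rather than a number. Compound 1 `CCc1nc(N)ncc1-c1ccc(Cl)cc1` likewise reaches only a limit in this assay, at > 400000 nM. Compound 3 `CCc1nc(N)nc(N)c1-c1cccc(C)c1` gives 34000 nM in this assay, a number rather than a limit. Compound 4 `CCCc1nc(N)nc(N)c1-c1ccc(Cl)cc1` differs from compound 2 by hydrogen in place of methyl on a saturated chain carbon, three bonds along the chain from an aromatic carbon, so butyl becomes propyl. Among the compounds with values here, no measured step covers this change, and the two limits leave no measured step from compound 2 to any other compound. Compound 3, carrying the shorter ethyl chain, gives 34000 nM, which suggests some gain may come with a shorter chain, though compound 3 differs from compound 2 in more than one place. The step this estimate implies is expected to be an at least 3.5-fold lower number from compound 2 to compound 4 (0.54 log units; beyond the scatter), modest and towards stronger inhibition. Compound 4 is estimated at 400000 nM, with a range from 60000 nM to 2000000 nM.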

Compound 4, half-maximal inhibitory concentration: 18000 nM
For compound 4 the middle estimate is 22-fold (1.35 log units) above the measured one; measured number outside the range, below it.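

Hydrogen in place of methyl on a saturated chain carbon, three bonds along the chain from an aromatic carbon, is the first single change in the series that can be read in this assay, and it gives an at least 77-fold lower number from compound 2 to compound 4 (1.89 log units; beyond the scatter). This chain position is therefore sensitive to a single methyl, and with chloro kept on the aryl group, butyl to propyl moves the series from a limit to a number. From the compounds shown here alone, the true size of the step remains unknown, because compound 2 stands at a limit of the assay and the step is only a bound: the limit of > 1400000 nM in this assay, at which 1 of the 4 values shown sits.

Compound 3 carries an ethyl chain but differs from compound 4 in more than one place, so it cannot show how a chain shorter than propyl behaves. Going by these compounds, whether a cyclopropyl group or an amine at the end of the propyl chain keeps the activity of compound 4 also remains open.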